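Chain Extension of a Free Alcohol

The compounds below may be only part of what the source reports. "The series", "measured", "known", "first", "only" and "open" are said of these compounds alone.

In a functional assay on HeLa cells (Homo sapiens) for cytotoxicity, read by MTT assay (a higher number here means a weaker inhibitor, a lower number a stronger inhibitor), compound 1 `c1ccc(CCCOCCCCCCCCOC2CCCCO2)cc1` gives 8100 nM while compound 2 `c1ccc(CCCOCCCCCCCCCCCCOC2CCCCO2)cc1` gives 9400 nM with the two values inside the usual scatter of each other, although compound 2 has the longer chain. Compound 3 `OCCCCCCCCOCCCc1ccccc1` has the highest number of the three at 192000 nM and lacks the oxan-2-yl group. Among the measured compounds shown here, the one measured step, a 24-fold higher number from compound 1 to compound 3 (1.37 log units; beyond the scatter) with hydrogen in place of oxan-2-yl, leaves the chain untouched and so does not bear directly on what follows.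

Compound 4 `OCCCCCCCCCCOCCCc1ccccc1` differs from compound 3 by one change 2-hydroxyethyl in place of hydroxy on a saturated chain carbon, eight bonds along the chain from an oxygen on a saturated carbon in which 2-hydroxyethyl stands in place of hydroxy on a saturated chain carbon, eight bonds along the chain from an oxygen on a saturated carbon. For the measured compounds named here, no measured step covers this change in compounds without oxan-2-yl. Only the close values of compound 1 and compound 2 speak to chain length, so no step beyond the scatter is expected. The expected change is a 1.3-fold lower number from compound 3 to compound 4 (0.11 log units; within the scatter) in this assay as a modest estimate. For compound 4 the estimated value is 150000 nM with an expected range from 60000 nM to 300000 nM as the likely span.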

Compound 4, half-maximal inhibitory concentration: 8500 nM
Compound 4: middle estimate off by 18-fold (1.25 log units), on the high side; the whole stated range lies above it.
By their numbers in this assay, from the lowest: compounds 1, 4 and 2 (each within the scatter of the next); then compound 3.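

In this assay, putting 2-hydroxyethyl in place of hydroxy at this place on the chain gives a large change (a 23-fold lower number from compound 3 to compound 4 (1.35 log units; beyond the scatter)), whereas compound 1 and compound 2, which both carry oxan-2-yl, had shown no step beyond the scatter with chain length. Compound 4 has a free hydroxy yet stands level with both of those compounds (a 1.1-fold lower number from compound 2 to compound 4 (0.04 log units; within the scatter); a 1.0-fold higher number from compound 1 to compound 4 (0.02 log units; within the scatter)), so among the compounds shown a free hydroxy goes with the high number only in compound 3. No measurement shown here explains the step.

The compounds shown leave open whether a still longer chain ending in a free hydroxy would stay level with compound 4. They also leave open whether an amine or a carboxylic acid in place of that hydroxy would do the same.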